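The source may hold more compounds than are shown below. What is called first, only, known or untested is meant among the compounds shown, and "the series" means these compounds.

Among the compounds with values here, compound 3 `CC(=O)c1ccccc1CC[C@H](SC[C@@H](C)C(=O)O)c1cccc(/C=C/c2ccc3ccc(Cl)cc3n2)c1` gives 3 nM in an assay on membranes from lung for inhibition of cysteinyl leukotriene receptor 1 (Cavia porcellus) (on this read-out lower numbers stand for stronger inhibition and higher numbers for weaker inhibition), the lowest of the three numbers measured so far. Compound 1 `CC(=O)c1cccc(CC[C@H](SC[C@@H](C)C(=O)O)c2cccc(/C=C/c3ccc4ccc(Cl)cc4n3)c2)c1` gives 5.9 nM, and compound 2 `COC(=O)c1cccc(CC[C@H](SC[C@@H](C)C(=O)O)c2cccc(/C=C/c3ccc4ccc(Cl)cc4n3)c2)c1` gives 7 nM. The steps between them are small: a 1.2-fold higher number from compound 1 to compound 2 (0.07 log units; within the scatter), a 2.0-fold lower number from compound 1 to compound 3 (0.29 log units; within the scatter) and a 2.3-fold lower number from compound 2 to compound 3 (0.37 log units; beyond the scatter). Compound 4 `C[C@H](CS[C@@H](CCc1ccccc1CC(C)(C)O)c1cccc(/C=C/c2ccc3ccc(Cl)cc3n2)c1)C(=O)O` differs from compound 3 in one place: 2-hydroxy-2-methylpropyl in place of acetyl on an aromatic carbon. Within the data shown here, none of the measured steps exchanges the acetyl for a hydroxyl-bearing chain, so they show only that the changes tried at this part of the molecule have shifted the numbers little. Compound 4 is therefore expected to give about 2.5 nM, with a range of 0.8 nM to 8 nM. That estimate corresponds to an expected step of a 1.2-fold lower number from compound 3 to compound 4 (0.08 log units; within the scatter).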

Compound 4, half-maximal inhibitory concentration: 1 nM
Estimate against measurement, compound 4: 2.5-fold (0.40 log units) above; the range from low to high includes it.
By their numbers in this assay, from the lowest: compound 4; then compounds 3, 1 and 2 (each within the scatter of the next, the first and the last beyond it).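

In this assay, a 2-hydroxy-2-methylpropyl chain, with more heavy atoms than acetyl and a hydrogen-bond donor that acetyl lacks, is accepted on this aromatic carbon, ortho to a large group, and the number falls beyond the scatter (a 3.0-fold lower number from compound 3 to compound 4 (0.48 log units; beyond the scatter)). The 2-(2-hydroxy-2-methylpropyl)phenyl group also gives wider gaps from the 3-substituted phenyl compounds (a 7.0-fold lower number from compound 2 to compound 4 (0.85 log units; beyond the scatter); a 5.9-fold lower number from compound 1 to compound 4 (0.77 log units; beyond the scatter)). No measurement here accounts for these falls. The compounds shown do not separate the hydroxyl from the added carbons. Going by these compounds, an amine in place of that hydroxyl, or a longer chain carrying it, remains open.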